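The source may report more compounds than this note shows. Statements on the series, on what has been measured and on what is new or still open speak of the compounds shown alone.

Compound 1 `Cc1nnc(SCC(=O)N/N=c2/scc(-c3ccc(Cl)cc3)n2-c2ccccc2)s1`: 34.1%
Compound 2 `O=C(CSc1ncccn1)N/N=c1/scc(-c2ccc(Br)cc2)n1-c1ccccc1`: 67.6%
Compound 3 `O=C(CSc1ncccn1)N/N=c1/scc(-c2ccc(Cl)cc2)n1-c1ccccc1`: 45.5%

Within the data shown here, in a functional assay on C6 cells (Rattus norvegicus) for cytotoxicity, read by MTT assay, with a stated time of 24 h, tested at 100 ug/mL (on this read-out lower numbers stand for a stronger effect and higher numbers for a weaker effect at the one concentration tested), compound 3 gives 45.5%, the second highest of the three numbers measured so far. Its nearest neighbour differs by one modest step: a number 11.4 percentage points higher from compound 1 to compound 3 (beyond the scatter). The furthest neighbour lies on the other side, again one modest step away: a number 22.1 percentage points lower from compound 2 to compound 3 (beyond the scatter).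

The next compound, compound 4 `COc1ccc(-c2cs/c(=N/NC(=O)CSc3ncccn3)n2-c2ccccc2)cc1`, differs from compound 3 in a single place: methoxy in place of chloro on an aromatic carbon. Among the measured compounds shown here, none of the measured steps puts a methoxy in this place, so there is no direct guide. For the measured compounds named here, the closest precedent is the halogen exchange, a number 22.1 percentage points lower from compound 2 to compound 3 (beyond the scatter), which shows that a swap at this same position of the ring can shift the read-out by a modest amount in either direction. The direction for a methoxy is open, so the expectation is wide.

Compound 4 is therefore expected to give about 55% in this assay, between 30% and 80%. That estimate means an expected step of a number 9.5 percentage points higher from compound 3 to compound 4 (within the scatter).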

Compound 4, a percentage reported as activity, at one concentration (the size of the read-out at that concentration, not a potency): 51.5%
Compound 4: the middle estimate sits 3.5 percentage points above what was measured, and the stated range covers the measured number.
By their numbers in this assay, from the lowest: compound 1; then compounds 3 and 4 (each within the scatter of the next); then compound 2.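

In this assay, the change from 4-chlorophenyl to 4-methoxyphenyl gives a number 6 percentage points higher from compound 3 to compound 4 (within the scatter), so on this aromatic carbon the two groups cannot be told apart, even though the methoxy adds a hydrogen-bond acceptor that the chloro lacks. The bromo now stands alone among the three groups at this place: alongside a number 22.1 percentage points lower from compound 2 to compound 3 (beyond the scatter), there is also a number 16.1 percentage points lower from compound 2 to compound 4 (beyond the scatter), so compound 2 shows the weaker effect against both of the others. Nothing available here accounts for this difference.

As far as these compounds go, it remains open whether a fluoro, a methyl or an amine on this carbon would read like the chloro and methoxy or like the bromo. From the compounds shown here alone, it is also open whether chloro and methoxy would still match with the 5-methyl-1,3,4-thiadiazol-2-yl group of compound 1 on the sulfur.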